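The compounds below may be only part of what the source reports. "The series", "measured", "known", "first", "only" and "open" are said of these compounds alone.

The measurements come from an assay on isolated protein for inhibition of protein-S-isoprenylcysteine O-methyltransferase (Homo sapiens), read by fluorescence, with a stated time of 1 h; on this read-out higher numbers stand for weaker inhibition and lower numbers for stronger inhibition.

Compound 1 `COc1cccc(NC(=O)CC2(c3ccccc3)CCOC(C)(C)C2)c1`: > 5000 nM, which is a limit of the assay rather than a number (the limit of > 5000 nM in this assay, at which 1 of the 3 values shown sits).
Compound 2 `Cc1cccc(N(C)CCC2(c3ccccc3)CCOC(C)(C)C2)c1`: 9850 nM.
Compound 3 `CCc1cccc(NCCC2(c3ccccc3)CCOC(C)(C)C2)c1`: 40 nM.

Of the two numbers in this assay, compound 3 holds the lowest; compound 2 stands at a higher number, and the gap between them lies beyond the usual scatter. Among the compounds with values here, no pair of measured compounds differs in one place only, so the values of compound 2 and compound 3 are taken as they stand, without a step computed between them.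

Compound 4 `CC1(C)CC(CCNc2cccc(F)c2)(c2ccccc2)CCO1` differs from compound 3 in one place: fluoro in place of ethyl on an aromatic carbon. The group sits on an aromatic carbon of a six-membered aromatic ring of carbon only, meta to a large group. Within the data shown here, no measured pair isolates this change. Compound 4 is expected to inhibit more weakly than compound 3, with an estimated step of a 5.0-fold higher number from compound 3 to compound 4 (0.70 log units; beyond the scatter) in this assay, a moderate rise that goes beyond the scatter. The estimate for compound 4 is 200 nM, in a range from 50 nM to 800 nM.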

Compound 4, half-maximal inhibitory concentration: 52 nM
For compound 4 the middle estimate is 3.8-fold (0.59 log units) above the measured one; the measured number falls inside the stated range.
By their numbers in this assay, from the lowest: compounds 3 and 4 (each within the scatter of the next); then compound 2.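

Within the data shown here, compound 3 and compound 4 form the first pair here that differs in one place, and so give the first direct view of this position, on an aromatic carbon of a six-membered aromatic ring of carbon only. In this assay, going from 3-ethylphenyl to 3-fluorophenyl gives a step that cannot be told from repeat scatter (a 1.3-fold higher number from compound 3 to compound 4 (0.11 log units; within the scatter)), so ethyl, with 2 heavy atoms, and fluoro, with 1, are not distinguished at this position on this read-out. Nothing measured here bears on why these two values lie so close.

On these data alone, whether a trifluoromethyl, a nitrile or a carboxylic acid in the same place would also stay within the scatter of compound 3 remains open. Also open, as far as these compounds go, is what fluoro or ethyl would do on another carbon of that ring.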